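A Tert-Butyl Exchange on a Saturated Chain Carbon

A few compounds are considered here, and "the series" means these few. Any claim that something is new, unique, unknown or untested is made for them only; others in the source may bear on it.

Compound 1 `O=C(NCc1cc(Cl)ccc1-n1cnnn1)[C@@H]1CC=NN1C(=O)[C@H](O)c1ccccc1`: 7 10^-6 cm/s
Compound 2 `CC1(C[C@@H](O)C(=O)N2N=CC[C@H]2C(=O)NCc2cc(Cl)ccc2-n2cnnn2)CC1`: 9.5 10^-6 cm/s

The two compounds were measured in an ADME assay on Caco-2 cells (Homo sapiens) for permeability, read by LC-MS, in the apical to basolateral direction, with a stated time of 60 min, at pH 6.5; a lower number here means that the compound crosses the layer more slowly, a higher number that the compound crosses the layer faster. There, compound 2 gives 9.5 10^-6 cm/s, which stands within the scatter of compound 1 at 7 10^-6 cm/s. The two numbers therefore cannot be told apart.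

The next compound to be measured is compound 3 `CC(C)(C)[C@@H](O)C(=O)N1N=CC[C@H]1C(=O)NCc1cc(Cl)ccc1-n1cnnn1`. Its difference from compound 2 is this: tert-butyl in place of (1-methylcyclopropyl)methyl on a saturated chain carbon bound to a carbonyl carbon and an oxygen on a saturated carbon. The change is tert-butyl in place of (1-methylcyclopropyl)methyl, on the same saturated chain carbon bound to a carbonyl carbon and an oxygen on a saturated carbon.

Among the measured compounds shown here, one measured step bears on it, made at that same place, where (1-methylcyclopropyl)methyl took the place of phenyl: a 1.4-fold higher number from compound 1 to compound 2 (0.13 log units; within the scatter). That step stayed within the scatter. For the measured compounds named here, no measured compound carries tert-butyl, so the data offer no direct reading of this group.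

On the strength of that one step, no change beyond the scatter is expected in this assay, and no direction is favoured. The expected step is a 1.1-fold lower number from compound 2 to compound 3 (0.05 log units; within the scatter). For compound 3 the estimate is 8.5 10^-6 cm/s, with an expected range of 4.5 10^-6 cm/s to 16 10^-6 cm/s.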

Compound 3, apparent permeability: 15 10^-6 cm/s
Beside the measured number, compound 3's estimate is 1.8-fold (0.25 log units) below it; the measured number falls inside the stated range.
By their numbers in this assay, from the lowest: compounds 1, 2 and 3 (each within the scatter of the next, the first and the last beyond it).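

In this assay the exchange itself gives a 1.6-fold higher number from compound 2 to compound 3 (0.20 log units; within the scatter), so tert-butyl and (1-methylcyclopropyl)methyl cannot be told apart at this saturated chain carbon bound to a carbonyl carbon and an oxygen on a saturated carbon. Among the compounds shown here, the new information lies in the comparison with phenyl at the same place (a 2.1-fold higher number from compound 1 to compound 3 (0.33 log units; beyond the scatter)): this is the first step at this position to pass beyond the scatter, if only modestly, so the group carried here can shift the number measurably, while compound 2 remains within the scatter of both compound 1 and compound 3. Nothing available accounts for this separation between phenyl and tert-butyl.

For the compounds shown here, with only three groups compared at one place on a single core, it remains open whether the separation would persist or widen with an isopropyl group, a cyclohexyl ring or an amine on that same carbon. As far as these compounds go, it is equally open whether the step from phenyl to tert-butyl would keep its direction and size if the rest of the molecule were different.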